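Halogen swap on a phenoxy chain, toxicity side

The compounds below may be only part of what the source reports. "The series", "measured", "known", "first", "only" and "open" are said of these compounds alone.

Three measured compounds share one core and a six-carbon chain ending in a halogenated aryl ether. Compound 1 `O=C1N(CCCCCCOc2ccc(Cl)cc2)CCN1c1cccnc1` was tested in a functional assay on cells (Homo sapiens) for cytotoxicity; a higher number here means that more compound is tolerated, a lower number that less compound is tolerated. In this assay compound 1 gives > 25000 nM, which is a limit of the assay and not a number. Compound 2 `O=C1N(CCCCCCOc2ccc(Br)cc2)CCN1c1cccnc1` carries bromo where compound 1 carries chloro. In this assay compound 2 gives > 25000 nM, again a limit rather than a number. Compound 3 `O=C1N(CCCCCCOc2ccc(Br)cc2)CCN1c1ccccc1` differs from compound 2 by phenyl in place of pyridin-3-yl on an amide-type nitrogen in a ring. In this assay compound 3 gives > 25000 nM, also a limit and not a number.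

The change from compound 2 to compound 1 is chloro in place of bromo on an aromatic carbon. Its size is a step that the two limits leave unreadable from compound 2 to compound 1, because every value sits at the limit of > 25000 nM in this assay, at which 3 of the 3 values shown sit.

Compound 4 `O=C1N(CCCCCCOc2ccc(Cl)cc2)CCN1c1ccccc1` has not yet been measured. It differs from compound 3 by chloro in place of bromo on an aromatic carbon. The place of this change is described in exactly the same words as for the change from compound 2 to compound 1, so it is the same change, made on the core that carries phenyl instead of pyridin-3-yl.

The step expected here is a number no higher from compound 3 to compound 4 (the limit leaves the size open), since nothing measured so far has shown a readable step. That expectation rests on compound 3 having given > 25000 nM, a limit of the assay. Compound 4 is therefore expected to give 25000 nM, most probably reported once more as a limit rather than a number.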

Compound 4, half-maximal cytotoxic concentration: > 25000 nM
Compound 4 ended at the assay's limit; the forecaster's own chance of this, stated with the estimate: 85%; the middle value sits exactly at the limit.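

Compound 4 also lands at the ceiling, so neither its comparison with compound 3 nor its comparison with compound 1 gives a readable step, because all the values sit at one limit: the limit of > 25000 nM in this assay, at which 4 of the 4 values shown sit.

The compounds shown leave open at what concentration any of the four becomes cytotoxic, and whether swapping bromo for chloro or pyridin-3-yl for phenyl changes that concentration at all.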